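Removing a Chloro Group: Compound 1 to Compound 3

This account rests on a few compounds, and the source may have more. Where it says the series, first, only, none or still open, it means among the compounds named here.

Compound 1 `N=C(N)c1ccc(-c2ccc(-c3ccc(Cl)cc3)o2)o1` was tested in a functional assay on PC-3 cells (Homo sapiens) for inhibition, read by sulforhodamine B assay, with a stated time of 48 h (on this read-out higher numbers stand for weaker inhibition of growth and lower numbers for stronger inhibition of growth), where compound 1 gives 1810 nM. Within the data shown here, the only other measured compound, compound 2 `N=C(N)c1ccc(-c2ccc(-c3cc(Cl)cc(Cl)c3)s2)s1`, gives 1880 nM in this assay. Compound 1 has the lower of the two numbers, but the gap to compound 2 lies within the scatter, so the two values show no difference that can be trusted.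

Compound 3 `N=C(N)c1ccc(-c2ccc(-c3ccccc3)o2)o1` has not yet been measured. It differs from compound 1 in one place: hydrogen in place of chloro on an aromatic carbon, para to a large group. Among the measured compounds shown here, no step between measured compounds covers this change, so nothing in the data shows its size. The step of a 1.4-fold higher number from compound 1 to compound 3 (0.16 log units; within the scatter) is expected to be small, toward weaker growth inhibition, at or just beyond the scatter. Compound 3 is accordingly estimated at 2600 nM, within a range from 1200 nM to 6500 nM.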

Compound 3, concentration for 50% growth inhibition: 2640 nM
For compound 3 the middle estimate is 1.0-fold (0.01 log units) below the measured one; the range from low to high includes it.
By their numbers in this assay, from the lowest: compounds 1, 2 and 3 (each within the scatter of the next).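

With the step of a 1.5-fold higher number from compound 1 to compound 3 (0.16 log units; within the scatter), the data in this assay give their first reading of what happens when chloro on this aromatic carbon, para to a large group, gives way to hydrogen. The step lies within the scatter, so compound 1 and compound 3 show no difference that can be trusted, and on this evidence the chloro group at this position is not needed to keep growth inhibition at this level. Nothing available bears on why the two compounds read alike.

The compounds shown leave open whether a larger or different group at this position, such as an amine, a carboxylic acid or a methoxy group, would move the number beyond the scatter. They also leave open whether removing chloro from compound 2 would give a similarly small step.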